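Chloro for Benzothiophene on the Amide of Compound 2

The source may hold more compounds than are shown below. What is called first, only, known or untested is meant among the compounds shown, and "the series" means these compounds.

The series shares one core carrying a secondary amine side chain and an amide-linked aryl group. Compound 1 `CCCNc1cc2c(cn1)cc(NC(=O)c1cccc(-c3ccccc3)c1)c(=O)n2C` pairs a propylamino chain with a biphenyl amide, compound 2 `CN(C)CCNc1cc2c(cn1)cc(NC(=O)c1cc3ccccc3s1)c(=O)n2C` and compound 3 `COc1cc(C(=O)Nc2cc3cnc(NCCN(C)C)cc3n(C)c2=O)cc(OC)c1OC` carry a dimethylaminoethylamino chain with a benzothiophene amide and a trimethoxyphenyl amide. In a functional assay on MDA-MB-468 cells (Homo sapiens) for antiproliferative activity, read by MTT assay, with a stated time of 48 h (on this read-out higher numbers stand for weaker inhibition and lower numbers for stronger inhibition), compound 2 gives 3570 nM, the second highest of the three numbers. Compound 1 gives 1870 nM, a gap to compound 2 that lies within the scatter. Compound 3 gives 15600 nM, which lies beyond the scatter above compound 2.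

Compound 4 `CN(C)CCNc1cc2c(cn1)cc(NC(=O)c1ccc(Cl)cc1)c(=O)n2C` is not yet measured. It differs from compound 2 in one place: 4-chlorophenyl in place of 1-benzothiophen-2-yl on a carbonyl carbon. Within the data shown here, no step between measured compounds isolates this exchange, so the expectation rests on the spread of the three amides seen so far, where the two non-methoxylated aryl amides of compound 1 and compound 2 sit close together.

Compound 4 is expected to give 5000 nM in this assay, within a range of 1500 nM to 16000 nM. The estimated step of a 1.4-fold higher number from compound 2 to compound 4 (0.15 log units; within the scatter) is not expected to exceed the scatter, with slight leaning toward a higher number.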

Compound 4, half-maximal inhibitory concentration: 1640 nM
Compound 4: middle estimate off by 3.0-fold (0.48 log units), on the high side, within the range that was stated.
By their numbers in this assay, from the lowest: compounds 4, 1 and 2 (each within the scatter of the next, the first and the last beyond it); then compound 3.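

In this assay, 4-chlorophenyl in place of 1-benzothiophen-2-yl on a carbonyl carbon gives a 2.2-fold lower number from compound 2 to compound 4 (0.34 log units; beyond the scatter), a modest step, and it shows that the number responds to the aryl group on this amide while the dimethylaminoethylamino chain stays the same. The second ring of the 1-benzothiophen-2-yl group and its sulfur are therefore not required for the activity of compound 2, as a single six-membered aromatic ring of carbon only, carrying chlorine, gives the lower number. No measurement at hand bears on why the number falls.

The compounds shown leave open whether this step belongs to the chlorine or to the phenyl ring itself, a question that a plain phenyl amide, a 4-fluorophenyl amide or a 4-methoxyphenyl amide on the same chain would address. As far as these compounds go, it also remains open whether the exchange gives the same step on another side chain, such as the propylamino chain of compound 1 or a longer dimethylaminopropylamino chain.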